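The source may report more compounds than this note shows. Statements on the series, on what has been measured and on what is new or still open speak of the compounds shown alone.

Measured so far:

Compound 1, `NC1(CN(C(=O)[C@@H]2C[C@H]2c2ccccc2)c2ccc(-c3ccccc3)cc2)CCCC1`: 0.57 nM
Compound 2, `CC[C@H](C)[C@H](N)CN(C(=O)[C@@H]1C[C@H]1c1ccccc1F)c1ccc(-c2ccccc2)cc1`: 650 nM

In a functional assay for agonist activity at G protein-coupled receptor 88 (Homo sapiens), read by HTRF and cAMP accumulation (a higher number here means that more compound is needed for the effect, a lower number that less compound is needed), compound 2 gives 650 nM, the higher of the two numbers recorded. Among the measured compounds shown here, compound 1, the only other compound measured, gives 0.57 nM in this assay, far below it and well beyond the usual scatter. The two compounds differ in more than one place. For the measured compounds named here, their values show only that compound 1 needs much less compound for the effect than compound 2; no single part of the structure can be singled out from them.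

Compound 3, `CC[C@H](C)[C@H](N)CN(C(=O)[C@@H]1C[C@H]1c1cccs1)c1ccc(-c2ccccc2)cc1`, keeps the amine-bearing chain and the biphenyl amide of compound 2 and changes only the aromatic group on the three-membered non-aromatic ring: thiophen-2-yl in place of 2-fluorophenyl on a saturated ring carbon. Going by the values given here, no measured pair shows what this kind of exchange does, so the expected step from compound 2 to compound 3 rests on the closeness of the two groups rather than on precedent. A small step, a 1.6-fold lower number from compound 2 to compound 3 (0.21 log units; within the scatter), toward a lower number is expected in this assay, likely within or just beyond the scatter. For compound 3 the estimated value in this assay is 400 nM, with a range from 100 nM to 1500 nM.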

Compound 3, half-maximal effective concentration: 360 nM
Compound 3: the middle estimate sits 1.1-fold (0.05 log units) above what was measured; the range from low to high includes it.
By their numbers in this assay, from the lowest: compound 1; then compounds 3 and 2 (each within the scatter of the next).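

Among the compounds shown here, this is the first step that changes one place alone, and it concerns the aromatic group on a saturated ring carbon of the three-membered ring. In this assay, thiophen-2-yl in place of 2-fluorophenyl gives a 1.8-fold lower number from compound 2 to compound 3 (0.26 log units; within the scatter), so the exchange leaves the number within the scatter, even though a six-membered aromatic ring of carbon only gives way to a five-membered aromatic ring with one hetero atom, and the fluorine leaves with it. This place therefore accepts both aromatic groups with no step that can be told from the scatter, although nothing available explains that outcome.

On these data alone, whether this holds for other groups in the same place, such as pyridin-2-yl or cyclohexyl, remains open, since a single exchange between two aromatic groups says little about a wider range of groups. Compound 1 differs from compound 2 and compound 3 in more than one place, so the part played by its amine-bearing ring, as against the chain of the other two, also stays unresolved, and a compound changing that part alone would be needed to separate it.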